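Chloro in place of hydrogen: a modest gain expected

The source may hold more compounds than are shown below. What is called first, only, known or untested is meant among the compounds shown, and "the series" means these compounds.

Compound 1, `Cc1cnc(Nc2ccc(S(C)(=O)=O)cc2)nc1Nc1nc2ccc(Cl)cc2s1`: 4180 nM
Compound 2, `CS(=O)(=O)c1ccc(Nc2nccc(Nc3nc4ccccc4s3)n2)cc1`: 11300 nM

Both were tested in a functional assay on HeLa cells (Homo sapiens) for antiproliferative activity, read by MTT assay, with a stated time of 48 h; on this read-out lower numbers stand for stronger inhibition and higher numbers for weaker inhibition. Compound 2 gives the higher of the two numbers, and compound 1 sits lower by a gap beyond the usual scatter. Compound 3, `CS(=O)(=O)c1ccc(Nc2nccc(Nc3nc4ccc(Cl)cc4s3)n2)cc1`, is not yet measured; it differs from compound 2 by chloro in place of hydrogen on an aromatic carbon. Compound 1 also carries a chloro group, but it differs from compound 2 in more than one place, so its lower number only partly speaks for this single change. Compound 3 is therefore expected to show a modest step toward a lower number, a 1.7-fold lower number from compound 2 to compound 3 (0.24 log units; within the scatter). Compound 3 is estimated at 6500 nM, within 2500 nM to 16000 nM.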

Compound 3, half-maximal inhibitory concentration: 1400 nM
Beside the measured number, compound 3's estimate is 4.6-fold (0.67 log units) above it, and the stated range ends above it.
By their numbers in this assay, from the lowest: compound 3; then compound 1; then compound 2.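

In this assay chloro in place of hydrogen on this aromatic carbon brings an 8.1-fold lower number from compound 2 to compound 3 (0.91 log units; beyond the scatter) and so gives this single change a size of its own. With chloro present on both sides, hydrogen in place of methyl on an aromatic carbon brings a 3.0-fold lower number from compound 1 to compound 3 (0.48 log units; beyond the scatter) as well, so the methyl of compound 1 goes with a higher number. Nothing here explains either step.

From the compounds shown here alone, whether bromo, methoxy or an amine on the same carbon would give a lower number stays open. So does whether chloro on another carbon of that ring would match this step.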